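The source may hold more compounds than are shown below. What is called first, only, known or untested is meant among the compounds shown, and "the series" means these compounds.

Three compounds share one core and differ only in the group carried on the oxygen attached to the aromatic ring. Compound 1 `CCCOc1ccc2c(c1)SCC(=O)N2` carries a propyl chain; in an assay on isolated protein for inhibition of Amine oxidase [flavin-containing] B (Homo sapiens), read by fluorescence and spectrophotometry, with a stated time of 20 min (a higher number here means a weaker inhibitor, a lower number a stronger inhibitor), compound 1 gives 2870 nM. Compound 2 `O=C1CSc2cc(OCC3CCCCC3)ccc2N1` has the larger saturated ring on that chain, and in this assay compound 2 gives 24 nM. That single change produces a 120-fold lower number from compound 1 to compound 2 (2.08 log units; beyond the scatter). Compound 3 `O=C1CSc2cc(OCc3ccc(Cl)cc3)ccc2N1`, with a chlorinated benzyl group in the same place, gives 2.7 nM and so stands with the lowest number of the three, well separated from both compound 2 and compound 1.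

Compound 4 `O=C1CSc2cc(OCc3ccc(Br)cc3)ccc2N1` is the next member. bromo in place of chloro on an aromatic carbon It is a swap of one halogen for another at the same spot on the ring, with nothing else altered. Within the data shown here, the only measured step, from compound 1 to compound 2, touches a different part of the molecule, so it offers no direct guide; no step between two halogens has been measured here. With no evidence either way, the change is expected to leave the number about where compound 3 sits, as a 1.1-fold lower number from compound 3 to compound 4 (0.03 log units; within the scatter), a step expected to stay within the scatter. Compound 4 is therefore estimated at 2.5 nM, in the range 1 nM to 7 nM.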

Compound 4, half-maximal inhibitory concentration: 4.1 nM
Compound 4: middle estimate off by 1.6-fold (0.21 log units), on the low side; the measured number falls inside the stated range.
By their numbers in this assay, from the lowest: compounds 3 and 4 (each within the scatter of the next); then compound 2; then compound 1.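

In this assay, the halogen exchange gives a 1.5-fold higher number from compound 3 to compound 4 (0.18 log units; within the scatter), so at this aromatic carbon, para to a large group, chloro and bromo cannot be told apart by these numbers. Among these compounds, the earlier compounds showed that changing the whole group on the oxygen can shift the number greatly, as in a 120-fold lower number from compound 1 to compound 2 (2.08 log units; beyond the scatter); this pair is the first to change a single atom on the benzyl ring while leaving that group otherwise intact, and here the result stays within the scatter. No outside measurement on these compounds bears on this result.

On these data alone, the two halogens alone cannot show how far this tolerance reaches, so it remains open whether fluoro, or a group that is not a halogen at all, such as methoxy, nitrile, an amine or a carboxylic acid, would leave the number in the same range. Also open, as far as these compounds go, is whether a chloro or bromo placed elsewhere on that ring, or a benzyl group with no halogen at all, would give a similar number.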